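A few compounds are considered here, and "the series" means these few. Any claim that something is new, unique, unknown or untested is made for them only; others in the source may bear on it.

Measured compounds:
compound 1, `COc1ccc(N/C=C\C(=O)c2cn(-c3ccccc3)nc2-c2ccccc2)cc1`: in a functional assay on U-87MG ATCC cells (Homo sapiens) for antiproliferative activity, read by MTT assay, with a stated time of 48 h (on this read-out higher numbers stand for weaker inhibition and lower numbers for stronger inhibition), compound 1 gives > 50000 nM, a limit of the assay rather than a number.
compound 2, `O=C(/C=C\Nc1ccc(C(F)(F)F)cc1)c1cn(-c2ccccc2)nc1-c1ccc(F)cc1`: in this assay compound 2 gives > 50000 nM, again a limit and not a number.

Compound 2 therefore stands at the edge of what this assay can report: both values shown sit at that same limit, as the limit of > 50000 nM in this assay, at which 2 of the 2 values shown sit, records, so no ordering between compound 1 and compound 2 can be read from these numbers.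

The next compound is compound 3, `COc1ccc(N/C=C\C(=O)c2cn(-c3ccccc3)nc2-c2ccc(F)cc2)cc1`. It differs from compound 2 in one place: methoxy in place of trifluoromethyl on an aromatic carbon. For the measured compounds named here, no measured pair shows what such a change does here, so there is no step to lean on. With compound 2 giving only a limit in this assay, the expected step from compound 2 to compound 3 is a step that the limit leaves unreadable from compound 2 to compound 3, meaning no change that would rise above the usual scatter, and most likely another limit. On that basis, compound 3 is estimated at 70000 nM in this assay, within a range from 20000 nM to 300000 nM.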

Compound 3, half-maximal inhibitory concentration: 2500 nM
Compound 3: middle estimate off by 28-fold (1.45 log units), on the high side; measured number outside the range, below it.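

In this assay, for the compounds shown here, compound 3 gives 2500 nM, the first true number in this set rather than a limit, so this series can show activity in these cells. Methoxy in place of trifluoromethyl on an aromatic carbon brings an at least 20-fold lower number from compound 2 to compound 3 (1.30 log units; beyond the scatter), and fluoro in place of hydrogen on an aromatic carbon brings an at least 20-fold lower number from compound 1 to compound 3 (1.30 log units; beyond the scatter). Compound 3 carries both the methoxy and the fluoro, whereas compound 1 lacks the fluoro and compound 2 lacks the methoxy, and both steps give only a minimum size because their starting values are limits, not numbers: the limit of > 50000 nM in this assay, at which 2 of the 3 values shown sit.

The compounds shown leave open whether methoxy is special or whether another group on the same aromatic carbon, such as an amine, a hydroxyl or a chlorine, would serve as well. They also leave open whether the fluoro can be swapped for another group, such as a chlorine or a methyl, and how far above the limit the true values of compound 1 and compound 2 lie.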